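The source may report more compounds than this note shows. Statements on the series, on what has been measured and on what is new or still open speak of the compounds shown alone.

Of the compounds shown here, three built on the same core have been tested in a functional assay on MIA PaCa-2 cells (Homo sapiens) for antiproliferative activity, read by MTT assay, with a stated time of 72 h; a higher number here means a weaker inhibitor, a lower number a stronger inhibitor. Compound 1, `COCn1c(=O)[nH]c(CC(COCc2ccccc2)COCc2ccccc2)c(C)c1=O`, gives 27300 nM. Compound 2, `Cc1c(CC(O)COCc2ccccc2)[nH]c(=O)[nH]c1=O`, returns only a limit of the assay, > 100000 nM. Compound 3, `Cc1c(CC(O)COCc2ccccc2)n(COCC[Si](C)(C)C)c(=O)[nH]c1=O`, likewise returns only a limit of the assay, > 100000 nM. Among the measured compounds shown here, the one change between measured compounds, a step that the two limits leave unreadable from compound 2 to compound 3, therefore cannot be read, and compound 3 stands at the limit of > 100000 nM in this assay, at which 2 of the 3 values shown sit, rather than at a number.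

Compound 4, `Cc1c(CC(O)CO)n(COCC[Si](C)(C)C)c(=O)[nH]c1=O`, differs from compound 3 by hydrogen in place of benzyl on an oxygen on a saturated carbon. For the measured compounds named here, no measured step removes a benzyl from such an oxygen, so no measured step bears directly on this change, and the single measured step gives no readable size to lean on. Compound 3 sits at the limit of > 100000 nM in this assay, at which 2 of the 3 values shown sit. The step that the limit leaves unreadable from compound 3 to compound 4 is consequently expected to be none beyond the scatter, with the result most likely reported again as a limit. Compound 4 is estimated at 150000 nM, between 50000 nM and 500000 nM.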

Compound 4, half-maximal inhibitory concentration: > 100000 nM
Compound 4: a limit, no number; the forecaster's own chance of this, stated with the estimate: 80%; the middle value lies beyond the limit too.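

Compound 3 and compound 4 both return only a limit of the assay, and the step between them cannot be read. Still open, going by these compounds, is whether hydrogen in place of benzyl on an oxygen on a saturated carbon changes activity at all in this assay for these compounds.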